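Replacing a Terminal Carbamoyl With Hydroxyamino on a Shared Core

A few compounds are considered here, and "the series" means these few. Any claim that something is new, unique, unknown or untested is made for them only; others in the source may bear on it.

Compound 1 `NC(=O)CCCCc1c[nH]c2ccc(F)cc12`: 39 nM
Compound 2 `NCC(N)CCc1c[nH]c2ccc(F)cc12`: 60 nM
Compound 3 `NC(=O)CCCc1c[nH]c2ccc(F)cc12`: 18 nM

In an assay on isolated protein (urine) for inhibition of Myeloperoxidase (Homo sapiens), with a stated time of 5 min (on this read-out higher numbers stand for weaker inhibition and lower numbers for stronger inhibition), compound 3 gives the lowest number of the three: a 2.2-fold lower number from compound 1 to compound 3 (0.34 log units; beyond the scatter) and a 3.3-fold lower number from compound 2 to compound 3 (0.52 log units; beyond the scatter) both lie beyond the scatter, so compound 3 stands apart from the other two. Compound 4 `ONCCCc1c[nH]c2ccc(F)cc12` carries the change (hydroxyamino in place of carbamoyl on a saturated chain carbon, three bonds along the chain from an aromatic carbon). Among the measured compounds shown here, no measured pair shows this same exchange. The step of a 2.2-fold lower number from compound 1 to compound 3 (0.34 log units; beyond the scatter) concerns chain length and is only loosely related; the step of a 3.3-fold lower number from compound 2 to compound 3 (0.52 log units; beyond the scatter) shows that swapping an amide-bearing group for one bearing nitrogen with hydrogens changed the number modestly. Compound 4 is therefore expected to land near compound 3, with a 1.4-fold higher number from compound 3 to compound 4 (0.14 log units; within the scatter) as the estimated step, giving an expected value of 25 nM within a range of 8 nM to 80 nM.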

Compound 4, half-maximal inhibitory concentration: 11 nM
Estimate against measurement, compound 4: 2.3-fold (0.36 log units) above, within the range that was stated.
By their numbers in this assay, from the lowest: compounds 4 and 3 (each within the scatter of the next); then compounds 1 and 2 (each within the scatter of the next).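

With this assay as the measure, hydroxyamino in place of carbamoyl, three bonds along the chain from an aromatic carbon, gives a 1.6-fold lower number from compound 3 to compound 4 (0.21 log units; within the scatter) and so cannot be told apart from carbamoyl here, even though the carbonyl has gone. The separation from the other two compounds also holds, with a 5.5-fold lower number from compound 2 to compound 4 (0.74 log units; beyond the scatter) in one comparison and a 3.5-fold lower number from compound 1 to compound 4 (0.55 log units; beyond the scatter) in the other. Nothing shown here explains why the two groups match. Still open, going by these compounds, is whether an amine or a carboxylic acid in the same place would read alike, and whether hydroxyamino would hold on a longer chain.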